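A cyclobutyl ester tested against an amide series

A few compounds are considered here, and "the series" means these few. Any claim that something is new, unique, unknown or untested is made for them only; others in the source may bear on it.

Of the compounds shown here, three sharing one core have been measured in an assay on membranes from HeLa cells for displacement of a labelled ligand from adenosine receptor A3 (Homo sapiens), read by scintillation counting, with a stated time of 180 min, tested at 1 uM; on this read-out lower numbers stand for less inhibition and higher numbers for more inhibition at the one concentration tested (going by the name of the read-out). Compound 1 `COC(=O)C1=C(C)NC(=O)NC1c1ccoc1` gives 2%, compound 2 `CC1=C(C(N)=O)C(c2ccoc2)NC(=O)N1` gives 2%, and compound 3 `CC1=C(c2ncc(C)o2)C(c2ccoc2)NC(=O)N1` gives 1%. Compound 2 stands level with compound 1 at the digits shown, and the two together are the highest of the three numbers, yet no change at the digits printed from compound 1 to compound 2 (within the scatter) and a number 1 percentage points lower from compound 2 to compound 3 (within the scatter) both lie within the scatter, so no ordering of the three can be drawn.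

The unmeasured compound 4 `CC1=C(C(=O)OC2CCC2)C(c2ccoc2)NC(=O)N1` differs from compound 2 in one place: cyclobutyloxy in place of amino on a carbonyl carbon. The step that bears most on this change is no change at the digits printed from compound 1 to compound 2 (within the scatter), the exchange of methoxy for amino at the same carbonyl carbon; compound 4 reverses that exchange toward an ester, now with a cyclobutyloxy group. The other two steps, a number 1 percentage points lower from compound 1 to compound 3 (within the scatter) and a number 1 percentage points lower from compound 2 to compound 3 (within the scatter), show that a larger change at that carbon also left the read-out flat. With every measured compound near the floor of the read-out and no step beyond the scatter, compound 4 is expected to show no step beyond the scatter either, and a number 1 percentage points higher from compound 2 to compound 4 (within the scatter) is the expected change. Compound 4 is accordingly estimated at 3%, within a range from -8% to 14%.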

Compound 4, a percentage reported as inhibition, at one concentration (the size of the read-out at that concentration, not a potency): 1%
Estimate against measurement, compound 4: 2 percentage points above; low and high end bracket the measured number.
By their numbers in this assay, from the lowest: compounds 3, 4, 1 and 2 (each within the scatter of the next).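

For the compounds shown here, with cyclobutyloxy on the carbonyl carbon, the shared core gained a four-membered non-aromatic ring of carbon only at this place for the first time, yet this assay showed no step beyond the scatter when this group replaced amino (a number 1 percentage points lower from compound 2 to compound 4 (within the scatter)). The comparison between the two esters, which differ only in cyclobutyl in place of methyl on the oxygen, gave the same reading (a number 1 percentage points lower from compound 1 to compound 4 (within the scatter)), so enlarging the group on that oxygen left the read-out flat in this pair, as the exchange of methoxy for amino had done. All four compounds now lie within the scatter of one another, and no group tried at this place separates from the rest. Nothing offered here gives a measured reason for this flat result.

The compounds shown leave open whether a carboxylic acid, an amine-bearing ester or a longer chain on the same carbonyl carbon would lift the read-out clear of the scatter. They also leave open whether a change elsewhere on the shared core would do so, since all four compounds differ only at this one place.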